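Benzyloxy to chloro(difluoro)methoxy on the shared core

A few compounds are considered here, and "the series" means these few. Any claim that something is new, unique, unknown or untested is made for them only; others in the source may bear on it.

Measured so far in an assay on mitochondria from L6 cells (Rattus norvegicus) for activation, with a stated time of 90 min; on this read-out lower numbers stand for an effect already at smaller amounts and higher numbers for an effect only at larger amounts of compound:
- Compound 1, `COc1cc(OC(F)(F)F)ccc1Nc1nc2nonc2nc1O`, gives 3800 nM.
- Compound 2, `Oc1nc2nonc2nc1Nc1ccc(OCC(F)(F)F)c(F)c1`, gives 10400 nM.
- Compound 3, `Oc1nc2nonc2nc1Nc1ccc(OCc2ccccc2)cc1`, gives 2400 nM.

Compound 3 sits at the low end of the three numbers. Against compound 1 the gap is within the scatter, so the two cannot be ordered; against compound 2 the gap is beyond the scatter, and compound 2 shows the larger number.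

Compound 4, `Oc1nc2nonc2nc1Nc1ccc(OC(F)(F)Cl)cc1`, has not yet been measured. It differs from compound 3 in one place: chloro(difluoro)methyl in place of benzyl on an oxygen on an aromatic ring.

Among the compounds with values here, no measured pair in this set isolates that change, so the expectation rests on the neighbourhood: compound 1 carries a trifluoromethoxy group on its ring and gives 3800 nM, a number within the scatter of compound 3. The step of a 1.7-fold higher number from compound 3 to compound 4 (0.22 log units; within the scatter) is therefore expected to be small, at most a modest move toward higher numbers, not clearly beyond the scatter. For compound 4 the estimate in this assay is 4000 nM, with a range from 1500 nM to 12000 nM.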

Compound 4, half-maximal effective concentration: 1900 nM
The estimate for compound 4 lay 2.1-fold (0.32 log units) above the measured number, and the stated range covers the measured number.
By their numbers in this assay, from the lowest: compounds 4, 3 and 1 (each within the scatter of the next); then compound 2.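

Within the data shown here, the first pair to isolate a single change at this place is chloro(difluoro)methyl in place of benzyl on an oxygen on an aromatic ring, which reads as a 1.3-fold lower number from compound 3 to compound 4 (0.10 log units; within the scatter) in this assay. In this pair, the six-membered aromatic ring of benzyl is not needed to keep the number in this range, as a smaller group with no ring gives a value that cannot be told apart from it. Nothing available bears on why the two groups read alike.

Still open, as far as these compounds go, is whether an amine or a carboxylic acid at the end of a longer chain on this oxygen would stay in the same range. From the compounds shown here alone, it is also open whether the exchange would read the same with a second group on the aromatic ring.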